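Series notes: two measured analogues and one awaiting measurement

The source may report more compounds than this note shows. Statements on the series, on what has been measured and on what is new or still open speak of the compounds shown alone.

compound 1, `Fc1cccc(-c2nn3c(CCc4ccccc4)nnc3s2)c1`: 18%
compound 2, `Fc1cccc(-c2nn3c(-c4ccccc4)nnc3s2)c1`: 15%

In an assay for inhibition of histone-lysine N-methyltransferase, H3 lysine-79 specific (Homo sapiens), with stated times of 15 min and 120 min, tested at 50 uM (a higher number here means more inhibition at the concentration tested (going by the name of the read-out), a lower number less inhibition), compound 1 gives 18% and compound 2 gives 15%. Compound 2 has the lower of the two numbers, but the gap to compound 1 lies within the scatter, so no order between them is claimed. Compound 3, `Fc1cccc(-c2nn3c(CN4CCCCC4)nnc3s2)c1`, differs from compound 2 by (piperidin-1-yl)methyl in place of phenyl on an aromatic carbon. For the measured compounds named here, no measured pair shows such a change, and both known values sit low, so in this assay no step beyond the scatter is expected in either direction. Compound 3 is estimated at 15%, with a range from 0% to 35%. The expected step is no change at the digits printed from compound 2 to compound 3 (within the scatter).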

Compound 3, a percentage reported as inhibition, at one concentration (the size of the read-out at that concentration, not a potency): 6%
Beside the measured number, compound 3's estimate is 9 percentage points above it; low and high end bracket the measured number.
By their numbers in this assay, from the lowest: compounds 3, 2 and 1 (each within the scatter of the next, the first and the last beyond it).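

In this assay the change to (piperidin-1-yl)methyl in place of phenyl gives a number 9 percentage points lower from compound 2 to compound 3 (within the scatter) and so does not separate the two groups at this aromatic carbon. Piperidin-1-yl in place of benzyl on the saturated chain carbon gives a number 12 percentage points lower from compound 1 to compound 3 (beyond the scatter) as the only step in the series beyond the scatter, and a modest one. Nothing on hand accounts for either step.

Open is whether an open-chain amine such as dimethylaminomethyl, or a carboxylic acid, on this carbon would lift the read-out clearly above the low numbers of the compounds shown.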